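The compounds below may be only part of what the source reports. "The series", "measured", "known", "first", "only" and "open" are said of these compounds alone.

In a functional assay on HCT-116 cells (Homo sapiens) for antiproliferative activity, read by CellTiter-Glo, with a stated time of 72 h (on this read-out lower numbers stand for stronger inhibition and higher numbers for weaker inhibition), compound 1 (`O=C(NO)c1ccc(/C=C/c2ccnc(-c3ccccc3O)c2)cc1`) gives 1450 nM while compound 2 (`O=C(NO)c1ccc(/C=C/c2ccnc(-c3cccc(O)c3)c2)cc1`) gives 1610 nM and compound 3 (`O=C(NO)c1ccc(/C=C/c2ccnc(-c3cccc(CO)c3)c2)cc1`) gives 1700 nM on the same read-out. Compound 3 stands level with both others, within the scatter (a 1.1-fold higher number from compound 2 to compound 3 (0.02 log units; within the scatter)) and (a 1.2-fold higher number from compound 1 to compound 3 (0.07 log units; within the scatter)). Compound 4 (`O=C(NO)c1ccc(/C=C/c2ccnc(-c3cccnc3)c2)cc1`) differs from compound 3 by pyridin-3-yl in place of 3-(hydroxymethyl)phenyl on an aromatic carbon. Those two steps and the third (a 1.1-fold higher number from compound 1 to compound 2 (0.05 log units; within the scatter)) all change this same substituent and none exceeds the scatter, but none brings in a ring nitrogen. No step beyond the scatter is therefore expected in this assay for this change, though with less certainty. The expected step is small (a 1.2-fold lower number from compound 3 to compound 4 (0.08 log units; within the scatter)). Compound 4 is estimated at 1400 nM (expected range 600 nM to 3200 nM).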

Compound 4, half-maximal inhibitory concentration: 5140 nM
The estimate for compound 4 lay 3.7-fold (0.56 log units) below the measured number, and the stated range ends below it.
By their numbers in this assay, from the lowest: compounds 1, 2 and 3 (each within the scatter of the next); then compound 4.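

In this assay, for the compounds shown here, pyridin-3-yl is the only group at this position whose steps pass the scatter (a 3.0-fold higher number from compound 3 to compound 4 (0.48 log units; beyond the scatter)) and (a 3.2-fold higher number from compound 2 to compound 4 (0.50 log units; beyond the scatter)) and (a 3.5-fold higher number from compound 1 to compound 4 (0.55 log units; beyond the scatter)), all modest. The position therefore responds to some aryl changes, although the 2-hydroxyphenyl, 3-hydroxyphenyl and 3-(hydroxymethyl)phenyl groups stay level with one another. No measurement shown bears on the origin of this step.

Going by these compounds, whether the ring nitrogen or the absence of a hydrogen-bond donor matters remains open. Unsubstituted phenyl and pyridin-3-yl carrying a hydroxymethyl group would separate the two.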